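The compounds below may be only part of what the source reports. "The series", "measured", "known", "first", "only" and "open" are said of these compounds alone.

Working notes on the series. Compound 3 `CCn1c(-c2ccc(C(F)(F)F)nc2)nc2c(O[C@H]3CCN(C(=O)c4cocn4)C3)ncnc21` is the low end of what has been measured in an ADME assay on the whole organism (Rattus norvegicus, strain Wistar Han) for metabolic stability; on this read-out higher numbers stand for fast clearance and lower numbers for slow clearance: compound 3 gives 13 mL/min/kg. Compound 1 `CCn1c(-c2cnc(C)nc2)nc2c(O[C@H]3CCN(C(=O)C4CC4)C3)ncnc21` stands nearest, and in this assay compound 1 gives 44 mL/min/kg. Compound 2 `CCn1c(-c2cnc(C)nc2)nc2c(N[C@H]3CCN(C(=O)C4CCC4)C3)ncnc21` lies furthest away, and in this assay compound 2 gives 320 mL/min/kg. Both gaps from compound 3 are beyond the scatter.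

The step under consideration leads to compound 4 `CCn1c(-c2ccc(C(F)(F)F)nc2)nc2c(O[C@H]3CCN(C(=O)N4CC(OC)C4)C3)ncnc21`, not yet measured in this assay. Relative to compound 3 the change is 3-methoxyazetidin-1-yl in place of 1,3-oxazol-4-yl on a carbonyl carbon; the shared core is untouched. Among the compounds with values here, no measured pair isolates this change, so the direction rests on compound 3 alone. The step from compound 3 to compound 4 is expected to stay within the scatter, at most a slight rise: a 1.5-fold higher number from compound 3 to compound 4 (0.19 log units; within the scatter). For compound 4 the estimate in this assay is 20 mL/min/kg, with a range from 8 mL/min/kg to 50 mL/min/kg.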

Compound 4, clearance: 29 mL/min/kg
Compound 4: the middle estimate sits 1.5-fold (0.16 log units) below what was measured; the measured number falls inside the stated range.
By their numbers in this assay, from the lowest: compound 3; then compounds 4 and 1 (each within the scatter of the next); then compound 2.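

In this assay, within the data shown here, 3-methoxyazetidin-1-yl in place of 1,3-oxazol-4-yl on the carbonyl carbon gives a 2.2-fold higher number from compound 3 to compound 4 (0.35 log units; beyond the scatter), the only step that isolates a change at this position. The position therefore responds to this exchange, though only modestly, and an aromatic five-membered ring can give way to a four-membered non-aromatic ring with a rise of that size. Nothing measured bears on the reason for this step.

The compounds shown leave open whether the rise follows the ring itself or its methoxy group. An unsubstituted azetidin-1-yl on the same carbonyl carbon would separate the two.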